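The source may hold more compounds than are shown below. What is called first, only, known or untested is meant among the compounds shown, and "the series" means these compounds.

Compound 1, `CCOC(=O)/N=C(/Nc1cccnc1)NC(C)(C)CC`, in a functional assay on the whole organism (blood, strain Wistar-Okamoto) with Rattus norvegicus as the target, with a stated time of 5 days (a lower number here means that less compound is needed, a higher number that more compound is needed for the effect), gives 20 mg/kg.
Compound 2, `CCC(C)(C)N/C(=N\C(N)=O)Nc1cccnc1`, in this assay gives only a limit of the assay, > 50 mg/kg.

Compound 2 therefore stands without a number of its own; its result is the limit of > 50 mg/kg in this assay, at which 1 of the 2 values shown sits, so only a lower bound on its dose is known. Within the data shown here, the step from compound 1 produced an at least 2.5-fold higher number from compound 1 to compound 2 (0.39 log units; beyond the scatter), the only measured step in this set and the only one that touches the group on the carbonyl carbon.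

The next compound, compound 3, `CCC(C)(C)N/C(=N\C=O)Nc1cccnc1`, differs from compound 2 by hydrogen in place of amino on a carbonyl carbon. Among the measured compounds shown here, that change sits at the same carbonyl carbon as the measured step, yet it does not reverse the earlier change, and no measured pair shows what the loss of the amino group does here. The starting point, compound 2, is itself a limit. The expected step from compound 2 to compound 3 can only be judged loosely; the estimate is a number no higher from compound 2 to compound 3 (the limit leaves the size open), leaning neither clearly up nor down beyond the scatter. For compound 3 in this assay the expected minimum effective dose is 50 mg/kg, with a range from 15 mg/kg to 150 mg/kg, and a real chance that again only a limit is reported.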

Compound 3, minimum effective dose: > 20 mg/kg
Compound 3: no number, only a limit (the forecaster's own chance of this, stated with the estimate: 50%); the middle value does not contradict the limit.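

With hydrogen in place of ethoxy on the carbonyl carbon, the result is a number no lower from compound 1 to compound 3 (the limit leaves the size open), so in this assay neither replacement of the ethoxy group shown here, amino or hydrogen, gives a lower number than compound 1 does. Compound 3 gives only a limit of the assay, > 20 mg/kg. Among these compounds, compound 1 therefore remains the only compound of the three with a number of its own, and the change from carbamoyl to formyl cannot be read, since the results of both compounds involved are limits.

The compounds shown leave open where the actual doses of compound 2 and compound 3 lie, and whether those two differ at all. They also leave open how a longer chain on the oxygen, such as propoxy, or a methyl group on the carbonyl carbon would compare with the ethoxy group of compound 1.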